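The source may hold more compounds than are shown below. What is called first, only, known or untested is meant among the compounds shown, and "the series" means these compounds.

In a functional assay for antagonist activity at transient receptor potential cation channel subfamily V member 1 (Homo sapiens), read by FLIPR and calcium flux (on this read-out lower numbers stand for stronger inhibition and higher numbers for weaker inhibition), compound 3 `O=C1COc2ccc(NC(=O)C3CCN(c4cc(F)c(F)c(F)c4)CC3)cc2N1` gives 59 nM, the lowest of the three measured values. Compound 2 `O=C1COc2ccc(NC(=O)C3CCN(c4ccccc4Br)CC3)cc2N1` gives 160 nM, and compound 1 `O=C1CSc2ccc(NC(=O)C3CCN(c4cc(F)c(F)c(F)c4)CC3)cc2N1` gives 1960 nM. Among the measured compounds shown here, the one step measured here, a 2.7-fold lower number from compound 2 to compound 3 (0.43 log units; beyond the scatter), shows how the aryl group on the ring nitrogen moves this read-out. Compound 4 `Cc1cccc(N2CCC(C(=O)Nc3ccc4c(c3)NC(=O)CO4)CC2)c1` differs from compound 3 only at that aryl group: 3-methylphenyl in place of 3,4,5-trifluorophenyl on an amine nitrogen in a ring. For the measured compounds named here, no measured step bears directly on a 3-methylphenyl group, so the expectation rests on compound 2 and compound 3 alone. Since the trifluorophenyl group sits at the lower end of the range seen, compound 4 is expected to give a somewhat higher number, a step of a 2.2-fold higher number from compound 3 to compound 4 (0.34 log units; beyond the scatter), landing near 130 nM with a range from 45 nM to 400 nM.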

Compound 4, half-maximal inhibitory concentration: 490 nM
The estimate for compound 4 lay 3.8-fold (0.58 log units) below the measured number, and the stated range ends below it.
By their numbers in this assay, from the lowest: compound 3; then compound 2; then compound 4; then compound 1.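

At the aryl group on the ring nitrogen, 3-methylphenyl in place of 3,4,5-trifluorophenyl gives an 8.3-fold higher number from compound 3 to compound 4 (0.92 log units; beyond the scatter), so this position can move the read-out further than compounds 2 and 3 had shown. The same group also gives a 3.1-fold higher number from compound 2 to compound 4 (0.49 log units; beyond the scatter), which places both halogen-bearing aryl groups, 2-bromophenyl and 3,4,5-trifluorophenyl, at lower numbers than 3-methylphenyl among these three compounds. Nothing available here explains these differences. The compounds shown leave open how an unsubstituted phenyl or a 3-chlorophenyl group would read at this position.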